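Swapping a quinoline for a thiazole on a nucleoside hydrazone

This account rests on a few compounds, and the source may have more. Where it says the series, first, only, none or still open, it means among the compounds named here.

Measured compounds:
- Compound 1, `CC(/C=N/Nc1nc(N)c2ncn([C@@H]3O[C@H](CO)[C@@H](O)[C@H]3O)c2n1)Cc1ccc(C(C)C)cc1`: 9500 nM
- Compound 2, `Nc1nc(N/N=C/c2ccc3ncccc3c2)nc2c1ncn2[C@@H]1O[C@H](CO)[C@@H](O)[C@H]1O`: 9.8 nM
- Compound 3, `Nc1nc(N/N=C/c2ccc(N(c3ccccc3)c3ccccc3)cc2)nc2c1ncn2[C@@H]1O[C@H](CO)[C@@H](O)[C@H]1O`: > 10000 nM

The three measured compounds share a nucleoside core and differ in the group hanging from the carbon with a double bond to nitrogen. They were tested in an assay on CHO-K1 cells for displacement of a labelled ligand from adenosine receptor A1 (Homo sapiens), read by scintillation counting, with a stated time of 60 min; on this read-out lower numbers stand for stronger inhibition and higher numbers for weaker inhibition. In this assay compound 2 gives 9.8 nM, which is the lowest of the two numbers obtained. Compound 1 gives 9500 nM, a far higher number, well beyond the scatter of repeated measurements. For compound 3 the assay reports only a limit, > 10000 nM, so no number is known for it; the limit of > 10000 nM in this assay, at which 1 of the 3 values shown sits, describes this situation.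

Compound 4, `Nc1nc(N/N=C/c2cncs2)nc2c1ncn2[C@@H]1O[C@H](CO)[C@@H](O)[C@H]1O`, has not yet been measured in this assay. It differs from compound 2 in one place: 1,3-thiazol-5-yl in place of quinolin-6-yl on a carbon with a double bond to nitrogen. For the measured compounds named here, no measured pair shows the effect of replacing a two-ring group with a single five-membered ring at this position, so the size of the step is uncertain. Going by the values given here, since the one small change away from compound 2 that is known, to compound 1, gives 9500 nM, a weakening is the more likely direction. The step from compound 2 to compound 4 is expected to be a 20-fold higher number from compound 2 to compound 4 (1.31 log units; beyond the scatter). Compound 4 is therefore estimated at 200 nM, with a plausible range from 30 nM to 3000 nM.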

Compound 4, inhibition constant: 22 nM
For compound 4 the middle estimate is 9.1-fold (0.96 log units) above the measured one, and the stated range ends above it.
By their numbers in this assay, from the lowest: compound 2; then compound 4; then compound 1. At a limit, above all of these: compound 3.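

In this assay, replacing quinolin-6-yl with 1,3-thiazol-5-yl on a carbon with a double bond to nitrogen gives a 2.2-fold higher number from compound 2 to compound 4 (0.35 log units; beyond the scatter), so the number does rise, but only modestly. This shows that the second ring of the quinolin-6-yl group is not needed for a low number at this position: with a single five-membered aromatic ring in place of a group of two six-membered aromatic rings, compound 4 still gives 22 nM. Nothing measured here explains why these two different groups give such close numbers.

The compounds shown leave open how a plain phenyl ring, a furan ring or a pyridine ring would behave at this position, and therefore whether the sulfur or the nitrogen of the 1,3-thiazol-5-yl group matters to the result. They also leave open whether adding a small group to the thiazole ring, such as a methyl, an amine or a carboxylic acid, would lower the number or raise it.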